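The source may report more compounds than this note shows. Statements on the series, on what has been measured and on what is new or still open speak of the compounds shown alone.

Compound 2 `N#C[C@H]1C[C@@H](CN([C@H](CCC(F)(F)F)C(N)=O)S(=O)(=O)c2ccc(Cl)cc2)C1` is the compound with the highest number among the two measured in an ADME assay on MDCKII-LE cells (Canis lupus familiaris) for permeability; on this read-out higher numbers stand for higher permeability and lower numbers for lower permeability; in this assay compound 2 gives 24.1 10^-6 cm/s. Among the measured compounds shown here, its only measured neighbour is compound 1 `N#C[C@@H]1C[C@H]1CN([C@H](CCC(F)(F)F)C(N)=O)S(=O)(=O)c1ccc(Cl)cc1`, which in this assay gives 9.94 10^-6 cm/s; the step of a 2.4-fold higher number from compound 1 to compound 2 (0.38 log units; beyond the scatter) is the single measured change in the set. Compound 3 `NC(=O)[C@@H](CCC(F)(F)F)N(CCCc1ncon1)S(=O)(=O)c1ccc(Cl)cc1` has not yet been measured. It differs from compound 2 in one place: 2-(1,2,4-oxadiazol-3-yl)ethyl in place of 3-cyanocyclobutyl on a saturated chain carbon bound to a sulfonamide nitrogen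

For the measured compounds named here, the one measured step, from compound 1 to compound 2, swaps a 2-cyanocyclopropyl for a 3-cyanocyclobutyl and does not bear directly on the change to compound 3, which exchanges the 3-cyanocyclobutyl for a 2-(1,2,4-oxadiazol-3-yl)ethyl; the data contain no comparison of this kind. In this assay compound 3 is therefore expected to show a modest drop, estimated as a 2.0-fold lower number from compound 2 to compound 3 (0.30 log units; within the scatter), in this assay. The estimate for compound 3 in this assay is 12 10^-6 cm/s, with a range from 5 10^-6 cm/s to 25 10^-6 cm/s.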

Compound 3, apparent permeability: 31.3 10^-6 cm/s
For compound 3 the middle estimate is 2.6-fold (0.42 log units) below the measured one, outside the stated range (above it).
By their numbers in this assay, from the lowest: compound 1; then compounds 2 and 3 (each within the scatter of the next).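

In this assay, the position on a saturated chain carbon bound to a sulfonamide nitrogen now shows that a very different group can stand there: exchanging the 3-cyanocyclobutyl for the 2-(1,2,4-oxadiazol-3-yl)ethyl, which has a five-membered aromatic ring and no nitrile, gives a 1.3-fold higher number from compound 2 to compound 3 (0.11 log units; within the scatter), so compound 2 and compound 3 cannot be told apart on this read-out. Replacing the 2-cyanocyclopropyl with the same group gives a 3.1-fold higher number from compound 1 to compound 3 (0.50 log units; beyond the scatter), which leaves compound 1 as the only one of the three set apart from the others, and shows that neither a nitrile nor a carbon-only ring is needed to reach the upper level in this small set. No measurement shown explains why these groups read as they do.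

With so few compounds, the result rests on a single example of a group without a nitrile. As far as these compounds go, how a plain propyl chain, or a chain ending in a primary amine or a carboxylic acid, would read at this position in this assay remains open, as does whether the 1,2,4-oxadiazole could give way to a simple phenyl ring with the same outcome.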